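From 3-oxomorpholin-4-yl to 4-methyl-2-oxopiperazin-1-yl

A few compounds are considered here, and "the series" means these few. Any claim that something is new, unique, unknown or untested is made for them only; others in the source may bear on it.

- Compound 1 `O=C1COCCN1c1ccc(C2CC(c3ccc([N+](=O)[O-])o3)=NO2)cn1`: 457 nm/s
- Compound 2 `O=C1COCCN1c1ccc(C2CC(c3ccc([N+](=O)[O-])o3)=NO2)cc1F`: 424 nm/s

In an ADME assay on Caco-2 cells (Homo sapiens) for permeability, read by HPLC, with a stated time of 2 h (a lower number here means that the compound crosses the layer more slowly, a higher number that the compound crosses the layer faster), compound 2 gives 424 nm/s, within the scatter of compound 1 at 457 nm/s, so the two cannot be ranked. Compound 3 `CN1CCN(c2ccc(C3CC(c4ccc([N+](=O)[O-])o4)=NO3)cc2F)C(=O)C1` carries 4-methyl-2-oxopiperazin-1-yl in place of 3-oxomorpholin-4-yl on an aromatic carbon, ortho to a fluoro group: 4-methyl-2-oxopiperazin-1-yl in place of 3-oxomorpholin-4-yl on an aromatic carbon. Within the data shown here, no measured pair shows this change, so the expectation is loosely held: a modest fall in this assay, probably not beyond the scatter. The expected step is a 1.3-fold lower number from compound 2 to compound 3 (0.11 log units; within the scatter). For compound 3 the estimated value is 330 nm/s, with an expected range of 170 nm/s to 560 nm/s.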

Compound 3, apparent permeability: 386 nm/s
Compound 3: middle estimate off by 1.2-fold (0.07 log units), on the low side, and the stated range covers the measured number.
By their numbers in this assay, from the lowest: compounds 3, 2 and 1 (each within the scatter of the next).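

Placing 4-methyl-2-oxopiperazin-1-yl in place of 3-oxomorpholin-4-yl, on an aromatic carbon ortho to a fluoro group, gives the only step at this position in this assay: a 1.1-fold lower number from compound 2 to compound 3 (0.04 log units; within the scatter). This read-out therefore does not separate the two groups on this compound pair. Nothing available bears on why the two groups read alike.

From the compounds shown here alone, whether the same holds for the core of compound 1 remains open. Going by these compounds, it is also open whether a carboxylic acid, a primary amine or a longer chain here would give a step beyond the scatter.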